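A few compounds are considered here, and "the series" means these few. Any claim that something is new, unique, unknown or untested is made for them only; others in the source may bear on it.

Compound 1 `Nc1nc2cc(Cl)c(Cl)cc2n1Cc1ccccc1`: 170000 nM
Compound 2 `Nc1nc2cc(Cl)c(Cl)cc2n1Cc1ccc([N+](=O)[O-])cc1`: 35000 nM
Compound 3 `Clc1cc2nc(Br)n(Cc3ccccc3)c2cc1Cl`: not yet measured

In a functional assay on KB cells (Homo sapiens) for inhibition (a higher number here means a weaker inhibitor, a lower number a stronger inhibitor), compound 1 gives 170000 nM, the higher of the two numbers. Compound 3 differs from it by bromo in place of amino on an aromatic carbon. Among the measured compounds shown here, the only measured step, a 4.9-fold lower number from compound 1 to compound 2 (0.69 log units; beyond the scatter), is modest and does not involve the group that changes here, so it is a loose guide. A modest step towards a lower number is therefore expected, though its direction is uncertain. The expected step is a 2.8-fold lower number from compound 1 to compound 3 (0.45 log units; beyond the scatter). For compound 3 the estimated value is 60000 nM, with an expected range from 15000 nM to 200000 nM.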

Compound 3, half-maximal inhibitory concentration: > 100000 nM
Compound 3: no number, only a limit; the forecaster's own chance of this, stated with the estimate: 20%; at least 1.6-fold (0.22 log units) between middle value and limit.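

In this assay compound 3 gives > 100000 nM, which is a limit and not a number, so no step from compound 1 to compound 3 can be read: the limit of > 100000 nM in this assay, at which 1 of the 3 values shown sits.

The compounds shown leave open how far, and in which direction, bromo in place of amino moves the number.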